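A few compounds are considered here, and "the series" means these few. Any claim that something is new, unique, unknown or untested is made for them only; others in the source may bear on it.

Within the data shown here, compound 3 `O=C1c2cc(COc3ccccc3)nn2CCN1c1cccnc1` holds the lowest of the three numbers so far: in a functional assay on HEK293 cells for positive allosteric modulation of metabotropic glutamate receptor 5 (Homo sapiens), read by calcium flux (on this read-out higher numbers stand for larger maximal responses and lower numbers for smaller maximal responses), compound 3 gives 64%. Its nearest neighbour is compound 2 `O=C1c2cc(COc3ccccc3)nn2CCN1c1ccccn1`, which in this assay gives 69%, the two lying within the usual scatter. Furthest away is compound 1 `O=C1c2cc(COc3ccccc3)nn2CCN1c1ccc(F)cc1F`, which in this assay gives 101%. The next compound, compound 4 `O=C1c2cc(COc3ccccc3)nn2CCN1c1ccncc1`, differs from compound 3 by pyridin-4-yl in place of pyridin-3-yl on an amide-type nitrogen in a ring. The step that bears most on this change, a number 5 percentage points lower from compound 2 to compound 3 (within the scatter), was within the scatter, whereas the replacements of 2,4-difluorophenyl, a number 32 percentage points lower from compound 1 to compound 2 (beyond the scatter) and a number 37 percentage points lower from compound 1 to compound 3 (beyond the scatter), were large. The expectation is therefore a number 2 percentage points lower from compound 3 to compound 4 (within the scatter), nothing beyond the scatter. Compound 4 is estimated at 62%, with a range from 45% to 80%.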

Compound 4, largest response reached (Emax), in percent of the reference or control that the assay uses: 72%
The estimate for compound 4 lay 10 percentage points below the measured number; low and high end bracket the measured number.
By their numbers in this assay, from the lowest: compounds 3, 2 and 4 (each within the scatter of the next); then compound 1.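

In this assay the change gives a number 8 percentage points higher from compound 3 to compound 4 (within the scatter) and, set against pyridin-2-yl, a number 3 percentage points higher from compound 2 to compound 4 (within the scatter) so the place of the nitrogen in the pyridine ring does not separate the three pyridinyl compounds. The step of a number 29 percentage points lower from compound 1 to compound 4 (beyond the scatter) shows that pyridin-4-yl, like the other two pyridinyl groups, stays beyond the scatter of the 2,4-difluorophenyl compound. Nothing shown gives a reason for this gap. Going by these compounds, whether a fluoropyridinyl group, or a phenyl carrying a single fluorine or a methoxy group, would lie closer to compound 1 remains open.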